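This account rests on a few compounds, and the source may have more. Where it says the series, first, only, none or still open, it means among the compounds named here.

Compound 2 `Cc1cc(O)c(C(C)C)cc1-c1cc(-c2ccco2)c(C#N)c(=O)[nH]1` gives 42.5% in a functional assay for inhibition, tested at 40 ug/mL; on this read-out higher numbers stand for a stronger effect at the one concentration tested and lower numbers for a weaker effect; compound 1 `COc1ccc(-c2cc(-c3cc(C(C)C)c(O)cc3C)[nH]c(=O)c2C#N)c(OC)c1` gives 37.5%, and the two numbers lie within the scatter of each other. Going by the values given here, the single measured step, a number 5 percentage points higher from compound 1 to compound 2 (within the scatter), went with furan-2-yl in place of 2,4-dimethoxyphenyl. Compound 3 `COc1ccc(-c2cc(-c3cc(C(C)C)c(O)cc3C)[nH]c(=O)c2C#N)cc1OC` carries 3,4-dimethoxyphenyl in place of furan-2-yl on an aromatic carbon. That step bears on it directly, since a dimethoxyphenyl group returns, though 3,4-dimethoxyphenyl rather than 2,4-dimethoxyphenyl; it was within the scatter, so no step beyond the scatter is expected, a number 4.5 percentage points lower from compound 2 to compound 3 (within the scatter). Compound 3 is therefore estimated at 38%, with a range from 25% to 52%.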

Compound 3, a percentage reported as inhibition, at one concentration (the size of the read-out at that concentration, not a potency): 44%
For compound 3 the middle estimate is 6 percentage points below the measured one; low and high end bracket the measured number.
By their numbers in this assay, from the lowest: compounds 1, 2 and 3 (each within the scatter of the next).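

Opposite the ring nitrogen, 3,4-dimethoxyphenyl, with 10 heavy atoms against 5 for furan-2-yl, gives a number 1.5 percentage points higher from compound 2 to compound 3 (within the scatter) in this assay, so this larger ring reads the same as the furan here. Shifting one methoxy group within the dimethoxyphenyl ring gives a number 6.5 percentage points higher from compound 1 to compound 3 (within the scatter), so that change also stays inside the noise. No measurement here explains why these groups read alike. On these data alone, whether an amine, a carboxylic acid or a longer alkyl chain at this position would read the same remains open. So does any stronger or weaker effect at other concentrations; each compound has a reading at only one concentration.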